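This account rests on a few compounds, and the source may have more. Where it says the series, first, only, none or still open, it means among the compounds named here.

Measured so far in a functional assay on SH-SY5Y cells (Homo sapiens) for antagonist activity, read by cAMP accumulation; a lower number here means a less potent compound, a higher number a more potent compound, by a factor of ten per unit of this negative logarithm:
- compound 1 `CCCCOc1ccc(Cc2ccc(NC3=NCCN3)cc2)cc1` gives 9
- compound 2 `CC(C)COc1ccc(Cc2ccc(NC3=NCCN3)cc2)cc1` gives 8.8
- compound 3 `COCCOc1ccc(Cc2ccc(NC3=NCCN3)cc2)cc1` gives 8

Compound 3 is the lowest of the three, beyond the scatter from both others. Compound 4 `c1cc(NC2=NCCN2)ccc1Cc1ccc(OCC2CCOCC2)cc1` carries oxan-4-yl in place of methoxymethyl on a saturated chain carbon bound to an oxygen on an aromatic ring. The closest measured change is the one at the same place (a number 0.80 log units lower from compound 2 to compound 3 (beyond the scatter)), which is modest, as is the other step into compound 3 (a number 1.00 log units lower from compound 1 to compound 3 (beyond the scatter)). The step between the other two (a number 0.20 log units lower from compound 1 to compound 2 (within the scatter)) stays within the scatter. Within the data shown here, no measured compound carries a ring here, so only part of that gap is expected back in this assay. The expected change is a modest rise (a number 0.40 log units higher from compound 3 to compound 4 (beyond the scatter)). For compound 4 the estimate is 8.4, with an expected range from 7.8 to 9.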

Compound 4, negative logarithm of the antagonist equilibrium constant: 8.5
The estimate for compound 4 lay 0.10 log units below the measured number; the range from low to high includes it.
By their numbers in this assay, from the lowest: compound 3; then compounds 4, 2 and 1 (each within the scatter of the next, the first and the last beyond it).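

In this assay a ring is accepted on a saturated chain carbon bound to an oxygen on an aromatic ring: oxan-4-yl in place of methoxymethyl gives a modest gain (a number 0.50 log units higher from compound 3 to compound 4 (beyond the scatter)), with one hydrogen-bond acceptor on each side of the change. Against the chains without oxygen, the picture is mixed (a number 0.30 log units lower from compound 2 to compound 4 (within the scatter); a number 0.50 log units lower from compound 1 to compound 4 (beyond the scatter)), so oxan-4-yl does not close the whole gap to propyl. No evidence at hand explains these steps.

The compounds shown leave open whether the ring itself or its oxygen accounts for the gain over methoxymethyl. Cyclohexyl or piperidin-4-yl in place of oxan-4-yl would separate the two.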